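Swapping an aryl ring for chlorine on the shared core

The compounds below may be only part of what the source reports. "The series", "measured", "known", "first", "only" and "open" are said of these compounds alone.

Of the compounds shown here, three of one series have been measured in a functional assay on CHO cells for antagonist activity at transient receptor potential cation channel subfamily V member 1 (Rattus norvegicus), read by calcium flux, at pH 5; a lower number here means a stronger inhibitor, a higher number a weaker inhibitor. Compound 1 `Fc1cc(F)cc(-c2nc(N3CCN(c4ncccc4C(F)(F)F)CC3)[nH]c2-c2ccc(C(F)(F)F)cc2)c1` gives 85 nM. Compound 2 `C[C@@H]1CN(c2ncccc2C(F)(F)F)CCN1c1nc(-c2ccccc2)c(-c2ccc(C(F)(F)F)cc2)[nH]1` gives 341 nM, and compound 3 `C[C@@H]1CN(c2ncc(CO)cc2Cl)CCN1c1nc(-c2cc(F)c(F)c(F)c2)c(-c2ccc(C(F)(F)F)cc2)[nH]1` gives 4 nM. On these numbers compound 1 stands second highest of the three: compound 2 shows a higher number, compound 3 a much lower one, and both gaps lie beyond the usual scatter. Compound 2 and compound 3 differ from compound 1 in more than one place, so no single step can be read off between them.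

Compound 4 `FC(F)(F)c1ccc(-c2[nH]c(N3CCN(c4ncccc4C(F)(F)F)CC3)nc2Cl)cc1` has not yet been measured. It differs from compound 1 in one way: chloro in place of 3,5-difluorophenyl on an aromatic carbon. An aromatic ring of the core is thus replaced by a single chlorine atom. Within the data shown here, no measured pair in this set isolates such a change. The ring that leaves is one the measured compounds all carry in some form, so a weakening is expected rather than none. Compound 4 is expected to give about 300 nM, in a range from 80 nM to 1500 nM, which would mean a step of a 3.5-fold higher number from compound 1 to compound 4 (0.55 log units; beyond the scatter).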

Compound 4, half-maximal inhibitory concentration: > 4000 nM
Compound 4 gave a limit, no number; the forecaster's own chance of this, stated with the estimate: 10%; middle value at least 13-fold (1.12 log units) away from the limit.
By their numbers in this assay, from the lowest: compound 3; then compound 1; then compound 2. At a limit, above all of these: compound 4.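

Among these compounds, replacing the 3,5-difluorophenyl group on the shared core with a lone chlorine atom gives an at least 47-fold higher number from compound 1 to compound 4 (1.67 log units; beyond the scatter), the first change in one place that can be read, and it is a large one. In this assay compound 4 gives only a limit, > 4000 nM, and not a number. This position therefore does not accept a lone chlorine in place of the aryl ring without a heavy loss of inhibition, although the true size of that loss stays unknown, since the step rests on this: the limit of > 4000 nM in this assay, at which 1 of the 4 values shown sits.

The compounds shown leave open whether an aromatic ring is needed at this carbon, or whether a methyl group, an amine or a pyridine ring could keep the inhibition. They also leave open whether the same swap would cost as much with the other groups of compound 3.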